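Carbamate Alkyl Variation in a Piperidine Ether Series

This account rests on a few compounds, and the source may have more. Where it says the series, first, only, none or still open, it means among the compounds named here.

Measured compounds:
compound 1 `CC(C)OC(=O)N1CCC(Oc2cccc3c2CCN3c2ccc(S(C)(=O)=O)cc2)CC1` — 70%
compound 2 `CC(C)OC(=O)N1CCC(Oc2ncnc3c2CCN3c2ccc(S(C)(=O)=O)cc2F)CC1` — 91%

Of the compounds shown here, two have been measured in a functional assay on CHO-K1 cells with Glucose-dependent insulinotropic receptor (Homo sapiens) as the target, read by a luciferase reporter, with a stated time of 5 h; on this read-out higher numbers stand for larger maximal responses and lower numbers for smaller maximal responses. Compound 1 reaches 70%, and compound 2 reaches 91%. Of the two numbers, compound 1 stands lowest; compound 2 lies a good distance higher, and this gap is beyond the usual scatter of repeated measurements. Compound 2 differs from compound 1 in more than one place, so nothing can be said about which of those changes carries the gap; the two values simply show that compound 2 gives the larger maximal response.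

The next compound, compound 3 `CC(C)(C)OC(=O)N1CCC(Oc2cccc3c2CCN3c2ccc(S(C)(=O)=O)cc2)CC1`, keeps the whole of compound 1 except at the carbamate end, where the change is methyl in place of hydrogen on a saturated chain carbon bound to an oxygen next to a carbonyl group and two saturated chain carbons. Among the compounds with values here, since the two measured compounds do not share a single-point difference, there is no measured step of this kind to lean on. A change this small, on the isopropoxycarbonyl group far from the rest of the molecule, is expected to move the maximal response little, so the step of a number 2 percentage points higher from compound 1 to compound 3 (within the scatter) is estimated to lie within the scatter, with no clear direction. Compound 3 is therefore expected to give about 72% in this assay, with a range from 55% to 90%.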

Compound 3, largest response reached (reported as percent of maximum), in percent of the reference or control that the assay uses: 92%
For compound 3 the middle estimate is 20 percentage points below the measured one; the measured number lies above the stated range.
By their numbers in this assay, from the lowest: compound 1; then compounds 2 and 3 (each within the scatter of the next).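

The carbamate end of compound 1 proves able to shift the maximal response. In this assay, the change from isopropoxycarbonyl to tert-butoxycarbonyl gives a number 22 percentage points higher from compound 1 to compound 3 (beyond the scatter), so methyl in place of hydrogen on this saturated chain carbon is enough on its own to produce a step beyond the scatter. The pair is the only one shown that differs in one place, and it therefore ties a change in response to a single site with the shared core held constant, which the gap between the two earlier compounds, differing in more than one place, could not do. Nothing measured here explains why this step occurs.

From the compounds shown here alone, whether the same change from isopropyl to tert-butyl would have any effect on the core of compound 2 remains open. Also open, going by these compounds, is how the maximal response would follow at this carbon with other groups, such as a longer chain, a cyclobutyl ring or a trifluoromethyl group.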